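Acetyl in Place of Methyl on a Fatty Acid Receptor Agonist

The source may hold more compounds than are shown below. What is called first, only, known or untested is meant among the compounds shown, and "the series" means these compounds.

Of the compounds shown here, two have been measured so far. Compound 1 `Cn1cncc1C(CC(=O)O)c1ccc(OCC2COc3ccc(Cl)cc3O2)cc1` is the weaker of the pair: in a functional assay on HEK293 cells for agonist activity at Free fatty acid receptor 1 (Homo sapiens), read by fluorescence and calcium flux, with a stated time of 10 min (a higher number here means a larger maximal response, a lower number a smaller maximal response), compound 1 reaches 62%. Compound 2 `CC#C[C@@H](CC(=O)O)c1ccc(OC[C@H]2COc3ccc(C)cc3O2)cc1` stands highest of the two numbers, since in this assay compound 2 reaches 78%, and the gap between compound 2 and compound 1 lies beyond the usual scatter of repeated measurements. Among the measured compounds shown here, no step between compounds that differ in a single place has been recorded, so the two values themselves are all that can be said of them.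

Compound 3 `CC#C[C@@H](CC(=O)O)c1ccc(OC[C@H]2COc3ccc(C(C)=O)cc3O2)cc1` is the next compound and has not yet been measured. It differs from compound 2 in one place: acetyl in place of methyl on an aromatic carbon. For the measured compounds named here, with no comparable step among the measured compounds to lean on, the account can only form an expectation from compound 2 alone. The step from compound 2 to compound 3 is expected to be small, a number 3 percentage points lower from compound 2 to compound 3 (within the scatter), most likely none beyond the scatter, with a slight lean downward. Compound 3 is therefore estimated to reach 75% in this assay, within a range from 55% to 95%.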

Compound 3, largest response reached (Emax), in percent of the reference or control that the assay uses: 51%
The estimate for compound 3 lay 24 percentage points above the measured number; the measured number lies below the stated range.
By their numbers in this assay, from the lowest: compound 3; then compound 1; then compound 2.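

In this assay, among the compounds shown here, the aromatic carbon that carries methyl in compound 2 proves not to be indifferent to its substituent: acetyl in place of methyl gives a number 27 percentage points lower from compound 2 to compound 3 (beyond the scatter), the first step in this account between compounds that differ in one place. The maximal response can therefore be moved from this position, which the earlier comparison of compound 1 and compound 2 could not show, as those two differ in more than one place. Acetyl enters with 3 heavy atoms and 1 hydrogen-bond acceptor where methyl has 1 heavy atom and none, and no measurement here explains the lower response or separates these two differences.

As far as these compounds go, what remains open is how an ethyl group, which keeps the carbon count of acetyl without its oxygen, would compare at this carbon, and whether a methoxy group or a nitrile would follow acetyl or methyl. Also open, from the compounds shown here alone, is whether a step of this size would recur on another core, as it rests on a single pair of compounds.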